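Methoxy in Place of Dimethylamino on the Benzyl Arm

The compounds below may be only part of what the source reports. "The series", "measured", "known", "first", "only" and "open" are said of these compounds alone.

Compound 1 `CCN(CCCOc1ccc(C(=O)/C=C/c2ccc(N(C)C)cc2)c(O)c1)Cc1ccc(N(C)C)cc1` gives 13700 nM in an assay on isolated protein for inhibition of Amine oxidase [flavin-containing] B (Homo sapiens); on this read-out higher numbers stand for weaker inhibition and lower numbers for stronger inhibition. Compound 2 `CCN(CCCCCCOc1ccc(C(=O)/C=C/c2ccc(N(C)C)cc2)c(O)c1)Cc1ccccc1N(C)C` gives 2100 nM in this assay.

Of these two numbers, compound 2 has the lower one, and its gap to compound 1 lies beyond the usual scatter. Compound 3 `CCN(CCCCCCOc1ccc(C(=O)/C=C/c2ccc(N(C)C)cc2)c(O)c1)Cc1ccccc1OC` has not been measured; it differs from compound 2 by methoxy in place of dimethylamino on an aromatic carbon. Going by the values given here, no measured pair shows this same change, so its direction is unknown. The step of a 1.4-fold higher number from compound 2 to compound 3 (0.15 log units; within the scatter) is expected to be small, likely within or near the scatter. Compound 3 is therefore estimated at 3000 nM, in a range from 1000 nM to 9000 nM.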

Compound 3, half-maximal inhibitory concentration: 700 nM
Compound 3: the middle estimate sits 4.3-fold (0.63 log units) above what was measured; the measured number lies below the stated range.
By their numbers in this assay, from the lowest: compound 3; then compound 2; then compound 1.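

Replacing dimethylamino with methoxy on this aromatic carbon gives a 3.0-fold lower number from compound 2 to compound 3 (0.48 log units; beyond the scatter) in this assay, so inhibition strengthens modestly but beyond the scatter. This shows that the group at this position affects the result and that dimethylamino is not required there for inhibition. No measurement available here explains the shift.

From the compounds shown here alone, whether a hydroxyl group, a fluorine atom or a plain hydrogen would serve this position as well remains open. So does whether methoxy would bring a similar gain with the chain of compound 1.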